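Amide side chain exchanged for a sulfonamide-bearing ring

This account rests on a few compounds, and the source may have more. Where it says the series, first, only, none or still open, it means among the compounds named here.

Measured compounds:
`CCn1cc(Nc2ncc3cccc(Nc4ccc(OC)cc4)c3n2)cn1` compound 1, > 1000 nM
`COCCNC(=O)CNc1ncc2c(Br)nn(-c3ccc4ncccc4c3)c2n1` compound 2, > 1000 nM

In an assay on isolated protein for inhibition of eIF-2-alpha kinase GCN2 (Homo sapiens) (on this read-out lower numbers stand for stronger inhibition and higher numbers for weaker inhibition), compound 1 gives only a limit of the assay, not a number. Compound 2 likewise returns only a limit in this assay, > 1000 nM, so no number stands for it. Both values shown sit at the limit of > 1000 nM in this assay, at which 2 of the 2 values shown sit, and compound 2 therefore cannot be placed relative to compound 1 beyond saying that both are limits.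

Compound 3, `CNS(=O)(=O)[C@@H]1CC[C@@H](Nc2ncc3c(Br)nn(-c4ccc5ncccc5c4)c3n2)C1`, differs from compound 2 by a group of 10 heavy atoms (6 carbon, 1 nitrogen, 2 oxygen, 1 sulfur; one five-membered non-aromatic ring of carbon only) in place of a group of 8 heavy atoms (5 carbon, 1 nitrogen, 2 oxygen; no ring), on a nitrogen on an aromatic ring. For the measured compounds named here, no measured step between compounds is available for this kind of change, so the expectation rests on the position of compound 2 alone. The step is expected to be a step that the limit leaves unreadable from compound 2 to compound 3, that is, none beyond the scatter of this assay. Compound 3 is thus estimated at 3000 nM, within a range from 800 nM to 12000 nM.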

Compound 3, half-maximal inhibitory concentration: 43 nM
Compound 3: middle estimate off by 70-fold (1.84 log units), on the high side, and the stated range ends above it.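

In this assay, the group on a nitrogen on an aromatic ring can move the read-out strongly: the exchange gives an at least 23-fold lower number from compound 2 to compound 3 (1.36 log units; beyond the scatter). Compound 3, at 43 nM, is the only compound shown with a number rather than a limit, so the core it shares with compound 2 can carry measurable inhibition once the ((2-methoxyethyl)carbamoyl)methyl group gives way to the sulfonamide-bearing five-membered ring. The step remains a bound rather than a size because compound 2 gives only a limit of the assay: the limit of > 1000 nM in this assay, at which 2 of the 3 values shown sit.

The ring, the sulfonamide and the two defined stereocentres enter together in one change, and the compounds shown do not separate their shares in the step. From the compounds shown here alone, whether an amine or a carboxylic acid in place of the sulfonamide on that ring would hold the value of compound 3 also stays open.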